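Anilide-free thiazolidinones: piperidinylethyl series cytotoxicity

The compounds below may be only part of what the source reports. "The series", "measured", "known", "first", "only" and "open" are said of these compounds alone.

Measured in an ADME assay on Vero cells (Chlorocebus sabaeus) for cytotoxicity, read by neutral red uptake, tested at 98 ug/mL; a lower number here means a stronger effect, a higher number a weaker effect of the compound at the concentration tested:
compound 1 `COc1ccc(C2SCC(=O)N2CCN2CCCCC2)cc1` gives 89%
compound 2 `O=C1CSC(c2ccc(F)cc2)N1CCN1CCCCC1` gives 87%
compound 3 `O=C1CSC(c2cccc(F)c2)N1CCN1CCCCC1` gives 92%

All three share one core and differ only in the aromatic substituent. The change methoxy in place of fluoro on an aromatic carbon gives a step of a number 2 percentage points higher from compound 2 to compound 1 (within the scatter). The two cores of compound 2 and compound 3 differ as 3-fluorophenyl in place of 4-fluorophenyl on a saturated ring carbon, with a step of a number 5 percentage points higher from compound 2 to compound 3 (within the scatter). Compound 3 thus stands with the highest number of the three, but its steps to compound 1 and compound 2 are within the scatter, so no order among them is claimed.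

Compound 4 `COc1cccc(C2SCC(=O)N2CCN2CCCCC2)c1` is not yet measured. It differs from compound 3 as methoxy in place of fluoro on an aromatic carbon. This is the same kind of change as from compound 2 to compound 1, but the place differs: there the methoxy sits para to a large group, here meta to it. Since that earlier step was a number 2 percentage points higher from compound 2 to compound 1 (within the scatter), the step from compound 3 to compound 4 is expected to be about a number 1 percentage points higher from compound 3 to compound 4 (within the scatter) in this assay. Compound 4 is therefore estimated at 93%, between 84% and 100%.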

Compound 4, a percentage reported as activity, at one concentration (the size of the read-out at that concentration, not a potency): 84%
Estimate against measurement, compound 4: 9 percentage points above; the range from low to high includes it.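

In this assay, methoxy in place of fluoro on an aromatic carbon, meta to a large group, gives a step of a number 8 percentage points lower from compound 3 to compound 4 (within the scatter). Set beside the same change on the other core, this step does not differ from the earlier one: the same change on two cores in this assay, a number 2 percentage points higher (within the scatter) from compound 2 to compound 1 and a number 8 percentage points lower (within the scatter) from compound 3 to compound 4, 10 percentage points apart, within the scatter of two such steps The change can therefore be carried between these two cores with no difference that this read-out can resolve, but this does not show that the change has no effect, that its place on the ring is irrelevant, or that the same would hold on any further core.

The compounds shown carry only fluoro and methoxy on the aromatic ring, so it remains open how an amine, a carboxylic acid or a nitrile there would read in this assay. Also open, from the compounds shown here alone, is whether a longer chain in place of the ethyl link of the piperidinylethyl arm would leave the read-out within the scatter of these four compounds.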